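A Single Chain Change in a Brain Inhibition Series

A few compounds are considered here, and "the series" means these few. Any claim that something is new, unique, unknown or untested is made for them only; others in the source may bear on it.

Measured compounds:
compound 1, `Cc1c(C)c2c(c(C)c1O)CC[C@@](C)(CC[N+](C)(C)C)O2`, 2300 nM
compound 2, `CCCCCCCCCCCCCCCCCCOC1=C(O)[C@@H](C(O)CO)OC1=O`, 6000 nM

In a functional assay (brain) for inhibition, with Rattus norvegicus as the target (on this read-out higher numbers stand for weaker inhibition and lower numbers for stronger inhibition), compound 1 gives the lowest of the two numbers shown. Compound 2, which shares no single-point relation with compound 1, gives a higher number, and the gap between the two lies beyond the usual scatter; nothing more can be drawn from that pair.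

Compound 3, `Cc1c(C)c2c(c(C)c1O)CC[C@@](C)(CC(=O)[N-][N+](C)(C)C)O2`, is not yet measured. It differs from compound 1 by a group of 7 heavy atoms (4 carbon, 2 nitrogen, 1 oxygen; no ring) in place of a group of 5 heavy atoms (4 carbon, 1 nitrogen; no ring), on a saturated chain carbon bound to a saturated ring carbon. Among the compounds with values here, no measured pair shows the effect of this change, so its size is unknown. Within the data shown here, the account expects no large step: compound 1 is taken as the reference, and the step from it to compound 3 in this assay is estimated as a 1.4-fold higher number from compound 1 to compound 3 (0.14 log units; within the scatter), within or just beyond the scatter, leaning toward weaker inhibition. Compound 3 is therefore expected at 3200 nM, with a range from 1000 nM to 10000 nM.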

Compound 3, half-maximal inhibitory concentration: 9000 nM
Compound 3: the middle estimate sits 2.8-fold (0.45 log units) below what was measured; measured number inside the range.
By their numbers in this assay, from the lowest: compound 1; then compounds 2 and 3 (each within the scatter of the next).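

In this assay, this position now has its first measured step: the group of 7 heavy atoms with no net charge, in place of the group of 5 heavy atoms with net charge +1, gives a 3.9-fold higher number from compound 1 to compound 3 (0.59 log units; beyond the scatter) on a saturated chain carbon bound to a saturated ring carbon. The change is modest, but it shows that, with the core of compound 1 held constant, this group can shift the read-out toward weaker inhibition. No available measurement bears on what lies behind this shift.

The change alters the atom count, the hydrogen-bond acceptor count and the net charge together, and the compounds shown do not separate these. They also leave open how a tertiary amine, a carboxylic acid or a longer chain would read out at this place.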